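Series notes: thiophen-2-yl in place of pyridin-4-yl

A few compounds are considered here, and "the series" means these few. Any claim that something is new, unique, unknown or untested is made for them only; others in the source may bear on it.

Measured so far in an assay on CHO cells for displacement of a labelled ligand from adenosine receptor A1 (Homo sapiens), read by scintillation counting, tested at 10 uM; on this read-out higher numbers stand for more inhibition at the one concentration tested (going by the name of the read-out) and lower numbers for less inhibition:
compound 1 `CC(C)(C)Cc1csc(N)c1C(=O)c1cccc(Cl)c1` gives 2%
compound 2 `CC(C)(C)Cc1c(-c2ccncc2)sc(N)c1C(=O)c1ccc(Cl)cc1` gives 1%
compound 3 `CC(C)(C)Cc1csc(N)c1C(=O)c1ccc(Cl)c(Cl)c1` gives 1%

Compound 2 stands level with compound 3 at the digits shown, the two together the lowest of the three numbers, while compound 1 sits one point higher; all three lie within the scatter of one another. Going by the values given here, the only single-place step measured, a number 1 percentage points lower from compound 1 to compound 3 (within the scatter), concerns a chloro on the benzoyl ring and not the position in question, so no measured step bears directly on the change thiophen-2-yl in place of pyridin-4-yl on an aromatic carbon that leads to compound 4 `CC(C)(C)Cc1c(-c2cccs2)sc(N)c1C(=O)c1ccc(Cl)cc1`. Among the compounds with values here, nothing so far moves beyond the scatter, so the step is expected to be a number 2 percentage points higher from compound 2 to compound 4 (within the scatter), none beyond the scatter. Compound 4 is therefore estimated at 3%, with a range from -4% to 12%.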

Compound 4, a percentage reported as inhibition, at one concentration (the size of the read-out at that concentration, not a potency): 1%
For compound 4 the middle estimate is 2 percentage points above the measured one; low and high end bracket the measured number.
By their numbers in this assay, from the lowest: compounds 2, 3, 4 and 1 (each within the scatter of the next).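

In this assay, going by these compounds alone, thiophen-2-yl in place of pyridin-4-yl gives no change at the digits printed from compound 2 to compound 4 (within the scatter) and so provides the first measured step at this position, on an aromatic carbon next to the ring sulfur. Neither ring lifts the number clear of the other compounds in the series at the one concentration tested. No measured evidence accounts for this result.

From the compounds shown here alone, whether a carboxylic acid, an aminomethyl group or a longer alkyl chain at this position would raise the inhibition stays open. The compounds shown also give no step from hydrogen to either ring with the benzoyl ring held the same.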